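A few compounds are considered here, and "the series" means these few. Any claim that something is new, unique, unknown or untested is made for them only; others in the source may bear on it.

Working notes on the series.

Compound 1 `O=C1NC(=S)S/C1=C\C=C\c1ccccc1` is the parent of this set. In an assay on isolated protein for inhibition of protein tyrosine phosphatase type IVA 3 (Homo sapiens), tested at 5 ug/mL (a lower number here means less inhibition, a higher number more inhibition at the concentration tested (going by the name of the read-out)), compound 1 gives 37.4%. Compound 2 `O=C1NC(=S)S/C1=C\C=C\c1ccccc1OCc1ccccc1C(F)(F)F` gives 40.8% and compound 3 `O=C1NC(=S)S/C1=C\C=C\c1ccccc1OCc1ccncc1` gives 39.4% in this assay. Compound 1 thus carries the smallest of the three numbers, with compound 3 nearest and compound 2 furthest, and both of those gaps lie within the scatter of repeated measurements.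

Compound 4 `O=C1NC(=S)S/C1=C\C=C\c1ccccc1OCc1ccccc1` has not yet been measured. Relative to compound 1 the change is benzyloxy in place of hydrogen on an aromatic carbon.

For the measured compounds named here, the one measured step that bears on this change is the one from compound 1 to compound 3, where (pyridin-4-yl)methoxy entered in place of hydrogen at the same position, giving a number 2 percentage points higher from compound 1 to compound 3 (within the scatter). Compound 2, which carries a larger ether group at that position, shows a number only a little above compound 1 and likewise within the scatter. Neither substitution at this aromatic carbon has moved the read-out beyond the scatter, so for benzyloxy no step beyond the scatter is expected in this assay.

The step from compound 1 to compound 4 is therefore estimated at a number 1.6 percentage points higher from compound 1 to compound 4 (within the scatter). Compound 4 is expected to give about 39%, with a range from 30% to 49%.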

Compound 4, a percentage reported as inhibition, at one concentration (the size of the read-out at that concentration, not a potency): 49.5%
For compound 4 the middle estimate is 10.5 percentage points below the measured one, and the stated range ends below it.
By their numbers in this assay, from the lowest: compounds 1, 3, 2 and 4 (each within the scatter of the next, the first and the last beyond it).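

In this assay substitution on this aromatic carbon, ortho to a large group, can move the read-out beyond the scatter: benzyloxy in place of hydrogen gives a number 12.1 percentage points higher from compound 1 to compound 4 (beyond the scatter) and is the only step of that kind from the parent among the compounds shown. For the compounds shown here, the ring at the end of the ether also counts, with phenyl in place of pyridin-4-yl giving a number 10.1 percentage points higher from compound 3 to compound 4 (beyond the scatter) and hydrogen in place of trifluoromethyl on that phenyl giving a number 8.7 percentage points higher from compound 2 to compound 4 (within the scatter) and so no step that can be told from the scatter. No measurement accompanying these numbers bears on what lies behind the steps.

Open, as far as these compounds go, is whether the ring at the end of the ether is needed at all, as a plain methoxy would show, and whether a longer chain between the oxygen and the phenyl keeps the number. Also open, from the compounds shown here alone, is how an amine or a carboxylic acid on that phenyl would read, and whether these differences at a single concentration would hold as differences in potency.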